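The source may report more compounds than this note shows. Statements on the series, on what has been measured and on what is new or still open speak of the compounds shown alone.

Among the measured compounds shown here, compound 2 `Cc1cc(C(=O)O)ccc1OCCCCOc1ccc(C(=O)CC2CCCC2)c(O)c1C` stands highest of the two numbers so far in an assay on HEK293 cells for positive allosteric modulation of metabotropic glutamate receptor 2 (Rattus norvegicus), read by thallium flux, with a stated time of 2.5 min (a higher number here means a larger maximal response, a lower number a smaller maximal response), giving 84.6%; the nearest is compound 1 `Cc1c(OCCCCOc2ccc(C(=O)O)c(Cl)c2)ccc(C(=O)CC2CCCC2)c1O`, which gives 80.8%, a gap within the scatter. For the measured compounds named here, the one measured step, a number 3.8 percentage points higher from compound 1 to compound 2 (within the scatter), also exchanges the carboxyphenyl group on an oxygen on a saturated carbon and stays within the scatter. Compound 3 `Cc1cc(OCCCCOc2ccc(C(=O)CC3CCCC3)c(O)c2C)ccc1C(=O)O` differs from compound 2 by 4-carboxy-3-methylphenyl in place of 4-carboxy-2-methylphenyl on an oxygen on a saturated carbon. Going by the values given here, only that step bears on it, so no step beyond the scatter is expected in this assay. Compound 3 is expected to reach 83%, between 70% and 96%. The expected step is a number 1.6 percentage points lower from compound 2 to compound 3 (within the scatter).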

Compound 3, largest response reached (reported as percent of maximum), in percent of the reference or control that the assay uses: 83.6%
The estimate for compound 3 lay 0.6 percentage points below the measured number; the measured number falls inside the stated range.
By their numbers in this assay, from the lowest: compounds 1, 3 and 2 (each within the scatter of the next).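

In this assay, 4-carboxy-3-methylphenyl in place of 4-carboxy-2-methylphenyl on an oxygen on a saturated carbon gives a number 1 percentage points lower from compound 2 to compound 3 (within the scatter), so this change of methyl placement is not resolved in the maximal response. Methyl in place of chloro on an aromatic carbon gives a number 2.8 percentage points higher from compound 1 to compound 3 (within the scatter), so that exchange is not resolved either. Nothing available accounts for either step. Still open, as far as these compounds go, is whether an amine or a nitrile on that aromatic carbon would hold the response within the scatter, and whether a tetrazole in place of the carboxylic acid would do so.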